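This account rests on a few compounds, and the source may have more. Where it says the series, first, only, none or still open, it means among the compounds named here.

The read-out here is a functional assay on MV4-11 cells (Homo sapiens) for antiproliferative activity, read by CellTiter-Glo, with a stated time of 72 h; on this read-out lower numbers stand for stronger inhibition of growth and higher numbers for weaker inhibition of growth. In it, compound 1 `N[C@H]1CC[C@H](CNc2cc(-c3csc(NCC4CCOCC4)n3)c(Cl)cn2)CC1` gives 1900 nM, which is a true number. Compound 2 `COCC(=O)N[C@H]1CC[C@H](Nc2cc(-c3csc(NCC4CCOCC4)n3)c(Cl)cn2)CC1` gives > 10000 nM. That value is a limit of the assay and not a number. Compound 2 thus stands at the limit of > 10000 nM in this assay, at which 1 of the 2 values shown sits.

The next compound, compound 3 `CCOCCN[C@H]1CC[C@H](Nc2cc(-c3csc(NCC4CCOCC4)n3)c(Cl)cn2)CC1`, keeps the rest of compound 2 and changes one group. It has 2-ethoxyethyl in place of (methoxymethyl)carbonyl on an amine nitrogen. The carbonyl leaves, and a plain chain without one enters. For the measured compounds named here, no two measured compounds differ in just one place, so no measured step shows what such a swap does.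

Going by the values given here, the only firm guide is compound 1 at 1900 nM, and a single compound is thin support. On that basis, inhibition of growth in this assay is expected to become stronger, by a step beyond the usual scatter. The expected change is an at least 10-fold lower number from compound 2 to compound 3 (1.00 log units; beyond the scatter). For compound 3 the estimated value is 1000 nM, within an estimated range of 200 nM to 5000 nM.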

Compound 3, concentration for 50% growth inhibition: 497 nM
Estimate against measurement, compound 3: 2.0-fold (0.30 log units) above, within the range that was stated.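

In this assay, putting 2-ethoxyethyl in place of (methoxymethyl)carbonyl on this amine nitrogen gives an at least 20-fold lower number from compound 2 to compound 3 (1.30 log units; beyond the scatter), so this single change takes the compound from no measurable growth inhibition in the tested range to a clear number. As far as these compounds go, compound 2 stands at a limit of the assay and not at a number, which means that the true size of the step remains unknown: the limit of > 10000 nM in this assay, at which 1 of the 3 values shown sits. The two groups hold the same count of heavy atoms, 5, so the step arises without any change in that count, while the carbonyl leaves and the chain enters with one oxygen fewer.

The step changes the carbonyl and the chain together, so it cannot say whether losing the carbonyl or gaining this particular chain matters more; a plain ethyl group, a longer ether chain or a free amine at this nitrogen would help separate the two. For the compounds shown here, compound 1 differs from both other compounds in more than one place, so its value gives no step that can be read at this position.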